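A few compounds are considered here, and "the series" means these few. Any claim that something is new, unique, unknown or untested is made for them only; others in the source may bear on it.

Within the data shown here, in a functional assay on A549 cells (Homo sapiens) for inhibition, read by colorimetric assay and MTT assay, with a stated time of 72 h (on this read-out higher numbers stand for weaker inhibition and lower numbers for stronger inhibition), compound 1 `Cc1ccc2c(c1)-c1cnc(n1C)OCCCCCCCCO2` gives 41000 nM and compound 2 `COc1ccc2c(c1)-c1cnc(n1C)OCCCCCCCCO2` gives 40000 nM, so compound 2 stands level with the only other measured compound, within the scatter. Compound 3 `Cn1c2cnc1OCCCCCCCCOc1ccc(F)cc1-2` differs from compound 2 by fluoro in place of methoxy on an aromatic carbon, with fluoro in place of methoxy on an aromatic carbon. Among the measured compounds shown here, the one measured step that bears on this is a 1.0-fold lower number from compound 1 to compound 2 (0.01 log units; within the scatter), for methoxy in place of methyl on an aromatic carbon. On that basis, no change beyond the scatter is expected in this assay, and the expected step is no change at the digits printed from compound 2 to compound 3 (within the scatter). Compound 3 is estimated at 40000 nM, within an expected range of 18000 nM to 85000 nM.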

Compound 3, half-maximal inhibitory concentration: 58000 nM
Estimate against measurement, compound 3: 1.5-fold (0.16 log units) below; the range from low to high includes it.
By their numbers in this assay, from the lowest: compounds 2, 1 and 3 (each within the scatter of the next).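

In this assay fluoro in place of methoxy gives a 1.5-fold higher number from compound 2 to compound 3 (0.16 log units; within the scatter) and fluoro in place of methyl gives a 1.4-fold higher number from compound 1 to compound 3 (0.15 log units; within the scatter). With a third group at this aromatic carbon, methyl, methoxy and fluoro all stand level within the scatter, so none of the exchanges shown here moves the number beyond it. Nothing measured on these compounds offers a reason for this result. On these data alone, whether an amine, a carboxylic acid or a longer chain at this position would shift the number beyond the scatter stays open.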